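The compounds below may be only part of what the source reports. "The series", "measured", "known", "first", "only" and "open" are said of these compounds alone.

Measured in an ADME assay on L6 cells (Rattus norvegicus) for cytotoxicity, read by resazurin assay, with a stated time of 72 h; on this read-out higher numbers stand for weaker inhibition and lower numbers for stronger inhibition:
- compound 1 `N=C(N)c1cccc(OCc2ccccc2)c1`: 156000000 nM
- compound 2 `N=C(N)c1ccc(COc2ccccc2)cc1`: 167000000 nM

Compound 2, at 167000000 nM, stands level with compound 1, as the two values lie within the usual scatter of each other. Compound 3 `N=C(N)c1ccc(COc2ccc(N)cc2)cc1` differs from compound 2 in one place: amino in place of hydrogen on an aromatic carbon. For the measured compounds named here, no measured pair shows the effect of this change in this assay. A modest step toward stronger inhibition is therefore expected, with little confidence in its size. The expected change is a 1.9-fold lower number from compound 2 to compound 3 (0.27 log units; within the scatter). The estimate for compound 3 is 90000000 nM, with a range of 30000000 nM to 200000000 nM.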

Compound 3, half-maximal inhibitory concentration: > 271000000 nM
Compound 3 gave a limit, no number; the forecaster's own chance of this, stated with the estimate: 15%; middle value at least 3.0-fold (0.47 log units) away from the limit.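

The reading for compound 3 is a limit, not a number: the limit of > 271000000 nM in this assay, at which 1 of the 3 values shown sits. In this assay, amino in place of hydrogen on an aromatic carbon, para to a large group, gives an at least 1.6-fold higher number from compound 2 to compound 3 (0.21 log units; that floor lies within the scatter), so the change can be bounded on one side only. For the compounds shown here, it shows no step toward stronger inhibition with amino at this position, something compounds 1 and 2, which carry only hydrogen on that ring, could not show.

As far as these compounds go, how far compound 3 lies past its limit stays open. So does whether a hydroxyl, a methoxy or a carboxylic acid on the same carbon would read alike.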